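Removing one ester group from compound 3

The source may hold more compounds than are shown below. What is called first, only, known or untested is meant among the compounds shown, and "the series" means these compounds.

- compound 1 `C=C1CC[C@@H]2[C@](C)(COC(=O)C3CCN(C)CC3)[C@H](OC(=O)C3CCN(C)CC3)CC[C@@]2(C)[C@@H]1/C=C/C1=CCOC1=O`: 2550 nM
- compound 2 `C=C1CC[C@@H]2[C@](C)(COC(=O)CCN(C)C)[C@H](OC(=O)CCN(C)C)CC[C@@]2(C)[C@@H]1/C=C/C1=CCOC1=O`: > 30000 nM
- compound 3 `C=C1CC[C@@H]2[C@](C)(COC(=O)CCCCC3CCSS3)[C@H](OC(=O)CCCCC3CCSS3)CC[C@@]2(C)[C@@H]1/C=C/C1=CCOC1=O`: 11700 nM

In a functional assay on KB cells (Homo sapiens) for inhibition, read by sulforhodamine B assay, with a stated time of 72 h (a lower number here means a stronger inhibitor of growth, a higher number a weaker inhibitor of growth), compound 3 at 11700 nM has the higher of the two numeric values, and compound 1 at 2550 nM lies lower, beyond the scatter. Compound 2 gives > 30000 nM as a limit, not a number.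

From compound 3 to compound 4 `C=C1CC[C@@H]2[C@](C)(COC(=O)CCCCC3CCSS3)[C@H](O)CC[C@@]2(C)[C@@H]1/C=C/C1=CCOC1=O` the change is a hydrogen atom in place of a group of 11 heavy atoms (8 carbon, 1 oxygen, 2 sulfur; one five-membered non-aromatic ring with 2 hetero atoms), on an oxygen on a saturated carbon and the group that leaves holds one five-membered non-aromatic ring with 2 hetero atoms. Within the data shown here, no measured step covers this change, so the range is kept wide. In this assay compound 3 gives 11700 nM, and compound 4 is expected to stay within the scatter of that value. The expected step is a 1.3-fold lower number from compound 3 to compound 4 (0.11 log units; within the scatter) in this estimate. For compound 4 the estimated value is 9000 nM with 3000 nM to 27000 nM as the expected range.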

Compound 4, concentration for 50% growth inhibition: > 30000 nM
Compound 4: a limit, no number; the forecaster's own chance of this, stated with the estimate: 15%; middle value at least 3.3-fold (0.52 log units) away from the limit.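

In this assay, this is the first step shown at the oxygen on a saturated carbon, and replacing the group there with a hydrogen atom gives an at least 2.5-fold higher number from compound 3 to compound 4 (0.40 log units; beyond the scatter). Compound 4 gives > 30000 nM, which is a limit and not a number, so only the lower bound of this step can be read. The true size of the step stays unresolved at the top of the readable range: the limit of > 30000 nM in this assay, at which 2 of the 4 values shown sit.

The compounds shown leave open whether a small acetyl group on this oxygen would retain the value of compound 3. They also leave open what the matching ester on the other oxygen contributes.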